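Moving a hydroxyl group around a phenyl ring

The compounds below may be only part of what the source reports. "The series", "measured", "known", "first", "only" and "open" are said of these compounds alone.

Of the compounds shown here, two in this small set have been tested in a functional assay on T47D cells (Homo sapiens) for cytotoxicity, read by CCK-8 assay; a lower number here means a stronger inhibitor, a higher number a weaker inhibitor. Compound 1, `Oc1cccc(-c2cc(-c3cccs3)cc(-c3cccc(O)c3)n2)c1`, gives 770 nM. Compound 2, `Oc1cccc(-c2cc(-c3ccccn3)cc(-c3ccccc3O)n2)c1`, gives 2560 nM. Compound 2 therefore stands at the highest of the two numbers, and its gap to compound 1 is wider than the usual scatter of repeated measurements. Compounds 1 and 2 differ in more than one place, so the two values alone cannot tell which part of the structure accounts for the gap.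

Compound 3, `Oc1cccc(-c2cc(-c3ccccn3)cc(-c3cccc(O)c3)n2)c1`, has not yet been measured in this assay. It keeps every atom of compound 2 but joins them differently: 3-hydroxyphenyl in place of 2-hydroxyphenyl on an aromatic carbon. Compound 3 thus carries the same two 3-hydroxyphenyl groups as compound 1, while keeping the pyridin-2-yl group of compound 2. Within the data shown here, no measured pair isolates this single change, so the direction of the step can only be guessed. The expected step of a 2.0-fold lower number from compound 2 to compound 3 (0.29 log units; within the scatter) is a modest move toward a lower number, between the two measured values. The estimate for compound 3 in this assay is 1300 nM, with a range from 500 nM to 3500 nM.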

Compound 3, half-maximal inhibitory concentration: 1410 nM
Compound 3: middle estimate off by 1.1-fold (0.04 log units), on the low side, within the range that was stated.
By their numbers in this assay, from the lowest: compounds 1, 3 and 2 (each within the scatter of the next, the first and the last beyond it).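

In this assay, putting 3-hydroxyphenyl in place of 2-hydroxyphenyl on the aromatic carbon next to the ring nitrogen gives a 1.8-fold lower number from compound 2 to compound 3 (0.26 log units; within the scatter), so the two placements of the hydroxyl group cannot be told apart in this pair. The same holds for the other single change now readable, pyridin-2-yl in place of thiophen-2-yl, which gives a 1.8-fold higher number from compound 1 to compound 3 (0.26 log units; within the scatter); compound 3 thus splits the wider gap between the two earlier compounds into two separate changes, and neither one alone stands clear of the scatter. Nothing in hand explains these numbers.

As far as these compounds go, the hydroxyl move has been seen only alongside a pyridin-2-yl group, so its size alongside thiophen-2-yl remains unknown. The compounds shown also leave open whether this position needs a hydroxyl group at all, a question that a plain phenyl, a 3-methoxyphenyl or a 3-aminophenyl group on the same carbon could help to answer.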